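A few compounds are considered here, and "the series" means these few. Any claim that something is new, unique, unknown or untested is made for them only; others in the source may bear on it.

Measured compounds:
- compound 1, `O=c1c2cccnc2ccn1[C@@H]1O[C@H](COP(=O)(O)OP(=O)(O)OP(=O)(O)O)[C@@H](O)[C@H]1O`, 35 nM
- compound 2, `N#Cc1ccc2c(=O)n([C@@H]3O[C@H](COP(=O)(O)OP(=O)(O)OP(=O)(O)O)[C@@H](O)[C@H]3O)ccc2c1`, 88 nM
- compound 3, `O=c1c2cc(Cl)ccc2ccn1[C@@H]1O[C@H](COP(=O)(O)OP(=O)(O)OP(=O)(O)O)[C@@H](O)[C@H]1O`, 10 nM

All three share a core built around a triphosphate sugar; they differ only in what sits on the fused aromatic ring. They were compared in a functional assay for agonist activity at P2Y purinoceptor 2 (Homo sapiens), read by FLIPR; on this read-out higher numbers stand for an effect only at larger amounts of compound and lower numbers for an effect already at smaller amounts. Compound 1 carries no substituent on that ring and gives 35 nM. Compound 2 carries a nitrile and gives 88 nM. Compound 3 carries a chloro group and gives 10 nM, the lowest number of the three; its gap to compound 1 and its larger gap to compound 2 both lie beyond the usual scatter, so among these three compound 3 is the most potent.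

Compound 4, `CSc1ccc2ccn([C@@H]3O[C@H](COP(=O)(O)OP(=O)(O)OP(=O)(O)O)[C@@H](O)[C@H]3O)c(=O)c2c1`, has not yet been measured in this assay. It is compound 3 with one change: methylsulfanyl in place of chloro on an aromatic carbon, in words, methylsulfanyl in place of chloro on an aromatic carbon. For the measured compounds named here, both groups are small and neither carries a charge, and no measured pair here shows what such a swap does. The expectation is therefore a step from compound 3 to compound 4 of a 1.5-fold higher number from compound 3 to compound 4 (0.18 log units; within the scatter), that is, little movement, possibly a slight shift toward a higher number. Compound 4 is estimated at 15 nM in this assay, within a range from 5 nM to 50 nM.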

Compound 4, half-maximal effective concentration: 140 nM
Compound 4: the middle estimate sits 9.3-fold (0.97 log units) below what was measured, outside the stated range (above it).
By their numbers in this assay, from the lowest: compound 3; then compound 1; then compounds 2 and 4 (each within the scatter of the next).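

In this assay, this place on the aromatic ring of carbon only turns out to be highly sensitive to what sits on it: methylsulfanyl in place of chloro gives a 14-fold higher number from compound 3 to compound 4 (1.15 log units; beyond the scatter) and so a large loss of potency. The earlier compounds shown here could not show this, since no two of them differ in one place only, and the change itself looks modest on paper, with 2 heavy atoms entering where 1 left, 1 hydrogen-bond acceptor gained and no net charge on either group. No measurement shown here explains why so small a swap moves the number so far.

The compounds shown leave open whether the loss goes with the sulfur atom, with the added carbon, or with the two together, and a methoxy, a methyl or a bromo group on this same carbon would help to separate those possibilities. They also leave open how far the number would move with a longer chain such as ethylsulfanyl, or with an amine or a carboxylic acid, at this place.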